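A few compounds are considered here, and "the series" means these few. Any claim that something is new, unique, unknown or untested is made for them only; others in the source may bear on it.

Going by the values given here, compound 2, with structure `CC(=O)OC[C@H]1O[C@@H](n2cc(CN3C(=O)/C(=C/c4ccco4)c4ccccc43)nn2)[C@H](OC(C)=O)[C@@H](OC(C)=O)[C@@H]1OC(C)=O`, is one of two compounds measured in a functional assay on A549 cells (Homo sapiens) for cytotoxicity, read by sulforhodamine B assay, with a stated time of 48 h (a higher number here means a weaker inhibitor, a lower number a stronger inhibitor), where compound 2 gives 14500 nM. Among the compounds with values here, this is the lowest of the two numbers, yet its only neighbour, compound 1, with structure `CC(=O)OC[C@H]1O[C@@H](n2cc(CN3C(=O)/C(=C/c4ccc(C)cc4)c4ccccc43)nn2)[C@H](OC(C)=O)[C@@H](OC(C)=O)[C@@H]1OC(C)=O`, gives 16000 nM in this assay, and the step of a 1.1-fold lower number from compound 1 to compound 2 (0.04 log units; within the scatter) shows that the two cannot be told apart. Compound 3, with structure `CCC/C=C1/C(=O)N(Cc2cn([C@@H]3O[C@H](COC(C)=O)[C@@H](OC(C)=O)[C@H](OC(C)=O)[C@H]3OC(C)=O)nn2)c2ccccc21`, is not yet measured; it differs from compound 2 by propyl in place of furan-2-yl on a double-bonded chain carbon bound to a double-bonded ring carbon. Within the data shown here, the single measured step at this position, a 1.1-fold lower number from compound 1 to compound 2 (0.04 log units; within the scatter), exchanged one ring for another and stayed within the scatter, so it bears on the new change only as a sign that this position has so far tolerated variation; a ring-to-chain exchange has no direct precedent here. Compound 3 is therefore expected to show no step beyond the scatter, estimated at 20000 nM with a range from 7000 nM to 55000 nM, which means an expected step of a 1.4-fold higher number from compound 2 to compound 3 (0.14 log units; within the scatter).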

Compound 3, half-maximal inhibitory concentration: 24100 nM
Estimate against measurement, compound 3: 1.2-fold (0.08 log units) below; low and high end bracket the measured number.
By their numbers in this assay, from the lowest: compounds 2, 1 and 3 (each within the scatter of the next).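

The new result carries the tolerance at this position from a ring-for-ring exchange to a ring-to-chain exchange. In this assay, propyl in place of furan-2-yl gives a 1.7-fold higher number from compound 2 to compound 3 (0.22 log units; within the scatter), and propyl in place of 4-methylphenyl gives a 1.5-fold higher number from compound 1 to compound 3 (0.18 log units; within the scatter), so among these three compounds neither an aromatic ring on the double-bonded chain carbon nor the hydrogen-bond acceptor of furan-2-yl shows a step beyond the scatter. Nothing at hand accounts for why the three numbers stay together.

From the compounds shown here alone, whether any group at this position can move the number beyond the scatter remains open. An amine, a carboxylic acid or a longer chain in place of propyl would bear on that question, and the compounds shown say nothing about changes elsewhere on the shared core.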